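The source may hold more compounds than are shown below. What is called first, only, known or untested is meant among the compounds shown, and "the series" means these compounds.

Compound 2 `N=C(NCCCc1c[nH]cn1)NC(=O)CC(c1ccc(F)c(F)c1)c1nccn1Cc1ccccc1` stands at the higher of the two numbers measured in a functional assay on cardiac atrium for agonist activity at histamine H2 receptor (Cavia porcellus); a lower number here means that less compound is needed, a higher number that more compound is needed for the effect: compound 2 gives 398 nM, while compound 1 `N=C(NCCCc1c[nH]cn1)NC(=O)CC(c1ccccc1)c1ccc(F)c(F)c1` gives 53.7 nM. Within the data shown here, the only measured step joins these two, a 7.4-fold higher number from compound 1 to compound 2 (0.87 log units; beyond the scatter). Compound 3 `N=C(NCCCc1c[nH]cn1)NC(=O)CC(c1ccc(F)c(F)c1)c1ncc[nH]1` is made from compound 2 by a smaller change: hydrogen in place of benzyl on an aromatic nitrogen. Among the measured compounds shown here, no measured step removes a benzyl from such a ring nitrogen, so the step from compound 1 to compound 2, which exchanged the whole aromatic ring on the saturated chain carbon, shows only that this part of the molecule matters by a modest amount and gives no direction for removing the benzyl alone. A modest step either way is possible, with a slight lean toward a higher number, and the estimated step for compound 3 is a 1.5-fold higher number from compound 2 to compound 3 (0.18 log units; within the scatter). Compound 3 is expected to give 600 nM in this assay. The expected range for compound 3 runs from 200 nM to 2000 nM.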

Compound 3, half-maximal effective concentration: 97.7 nM
Compound 3: the middle estimate sits 6.1-fold (0.79 log units) above what was measured, and the stated range ends above it.
By their numbers in this assay, from the lowest: compounds 1 and 3 (each within the scatter of the next); then compound 2.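

Removing the benzyl from the ring nitrogen gives a 4.1-fold lower number from compound 2 to compound 3 (0.61 log units; beyond the scatter) in this assay, so the earlier rise, a 7.4-fold higher number from compound 1 to compound 2 (0.87 log units; beyond the scatter), does not carry over to the imidazole ring without its benzyl. With 1H-imidazol-2-yl in place of phenyl, the result is a 1.8-fold higher number from compound 1 to compound 3 (0.26 log units; within the scatter) and this assay does not separate the two rings. No measurement available here explains either step.

Still open, on these data alone, is whether a methyl on the same ring nitrogen would give a number close to that of compound 3 or to that of compound 2. A longer chain there, such as 2-phenylethyl, is equally untested by the compounds shown, so the benzyl result cannot yet be extended to other groups on this nitrogen.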